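The source may report more compounds than this note shows. Statements on the series, on what has been measured and on what is new or still open speak of the compounds shown alone.

For the measured compounds named here, compound 2 `CC1(c2ccccc2)CC(=O)N(CC(=O)N2CCN(c3ccccc3)CC2)C1=O` is the only compound of this pair to return a number in a functional assay on the whole organism (strain CD-1) with Mus musculus as the target, with a stated time of 0.5 h; a higher number here means that more compound is needed for the effect, a lower number that less compound is needed: in this assay compound 2 gives 100 mg/kg. Compound 1 `Cc1cccc(N2CCN(C(=O)CN3C(=O)CC(C)(c4ccccc4)C3=O)CC2)c1` is the other member of the series; in this assay compound 1 is reported as "not active" (no number reported), without a number. Compound 3 `CC1(c2ccccc2)CC(=O)N(CC(=O)N2CCN(c3ncccn3)CC2)C1=O` is not yet measured. It differs from compound 2 by pyrimidin-2-yl in place of phenyl on an amine nitrogen in a ring. Going by the values given here, no measured step is known for this kind of change, so the expected step of no change at the digits printed from compound 2 to compound 3 (within the scatter) is none beyond the scatter. In this assay compound 3 is therefore estimated at 100 mg/kg, expected to fall between 50 mg/kg and 200 mg/kg.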

Compound 3, minimum effective dose: "not active" (no number reported)
Nothing numeric was reported for compound 3; no gap can be computed for the estimate.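

For the compounds shown here, compound 3 carries no number in this assay, and no step from compound 2 to compound 3 can be read. The compounds shown leave open how large any difference between phenyl and pyrimidin-2-yl is. No measured evidence bears on this result.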